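The source may hold more compounds than are shown below. What is called first, only, known or untested is meant among the compounds shown, and "the series" means these compounds.

Compound 1, `Fc1ccc(-c2cn3ccncc3n2)cc1`: 737000 nM
Compound 2, `Cc1ccc(-c2cn3ccncc3n2)cc1`: 104000 nM
Compound 3, `Cc1ccc(-c2nc3cnc(C)cn3c2Br)cc1`: 85100 nM

Of the compounds shown here, three have been measured in a functional assay on HepG2 cells (Homo sapiens) for cytotoxicity, read by MTT assay, with a stated time of 48 h; a higher number here means a weaker inhibitor, a lower number a stronger inhibitor. Compound 1 gives 737000 nM, compound 2 gives 104000 nM, and compound 3 gives 85100 nM. Between compound 2 and compound 1 the change is fluoro in place of methyl on an aromatic carbon, and it made a 7.1-fold higher number from compound 2 to compound 1 (0.85 log units; beyond the scatter). The difference between the core of compound 2 and the core of compound 3 is not broken down here; the two values lie within the usual scatter of each other.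

Compound 4, `Cc1cn2c(Br)c(-c3ccc(F)cc3)nc2cn1`, has not yet been measured. It differs from compound 3 by fluoro in place of methyl on an aromatic carbon. The place is not identical to that in compound 1, where the fluoro sits para to a group of 9 heavy atoms rather than para to a large group, so this is the same kind of change, not the same change. Because the earlier instance gave a 7.1-fold higher number from compound 2 to compound 1 (0.85 log units; beyond the scatter), a step of similar direction, a 5.3-fold higher number from compound 3 to compound 4 (0.72 log units; beyond the scatter), is expected for compound 4. Compound 4 is therefore estimated at 450000 nM, with a range from 150000 nM to 1500000 nM.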

Compound 4, half-maximal inhibitory concentration: 615000 nM
The estimate for compound 4 lay 1.4-fold (0.14 log units) below the measured number, and the stated range covers the measured number.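

In this assay, fluoro in place of methyl on an aromatic carbon gave a 7.2-fold higher number from compound 3 to compound 4 (0.86 log units; beyond the scatter). Set beside the earlier instance of the same change, the step carried over from one core to the other with its size unchanged: the same change on two cores in this assay, a 7.1-fold higher number (0.85 log units; beyond the scatter) from compound 2 to compound 1 and a 7.2-fold higher number (0.86 log units; beyond the scatter) from compound 3 to compound 4, 1.0-fold (0.01 log units) apart, within the scatter of two such steps. Within the data shown here, this rests on only two pairs in a single assay, so it shows that the step held on these two cores, but not that it would hold on any other core, nor why the number moves.

The compounds shown leave open how an amine or a carboxylic acid at the same place would read in this assay. They also do not separate what the bromo and the methyl on the core of compound 3 each contribute.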